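The source may report more compounds than this note shows. Statements on the series, on what has been measured and on what is new or still open speak of the compounds shown alone.

Compound 1 `Cc1ccc(S(=O)(=O)N[C@H]2C3CC[C@H](C3)[C@@H]2C/C=C\CCCC(=O)O)cc1` gives in a functional assay (plasma) for inhibition, with Oryctolagus cuniculus as the target (a lower number here means a stronger inhibitor, a higher number a weaker inhibitor), a value of 500 nM. Compound 2 `O=C(O)CCC/C=C\C[C@H]1[C@@H]2CCC(C2)[C@@H]1NS(=O)(=O)c1ccc(F)cc1` gives in this assay 600 nM; the step of a 1.2-fold higher number from compound 1 to compound 2 (0.08 log units; within the scatter) lies within the scatter, so the two are not told apart. Compound 3 `CCc1ccc(S(=O)(=O)N[C@H]2C3CC[C@H](C3)[C@@H]2C/C=C\CCCC(=O)O)cc1` gives in this assay 4600 nM, the highest of the three numbers and so the weakest inhibitor measured: from compound 2 the step is a 7.7-fold higher number from compound 2 to compound 3 (0.88 log units; beyond the scatter) and from compound 1 it is a 9.2-fold higher number from compound 1 to compound 3 (0.96 log units; beyond the scatter), both beyond the scatter.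

Compound 4 `CS(=O)(=O)N[C@H]1C2CC[C@H](C2)[C@@H]1C/C=C\CCCC(=O)O` is not yet measured. It differs from compound 3 by methyl in place of 4-ethylphenyl on a sulfonyl sulfur. Of the measured steps, a 9.2-fold higher number from compound 1 to compound 3 (0.96 log units; beyond the scatter) and a 7.7-fold higher number from compound 2 to compound 3 (0.88 log units; beyond the scatter) bear on it, since both alter the same 4-ethylphenyl end of the molecule that is now replaced; each raised the number beyond the scatter when the group on that ring was changed. For the measured compounds named here, no measured step removes the ring itself, so the present change has no direct precedent and its size is uncertain. Because both a 9.2-fold higher number from compound 1 to compound 3 (0.96 log units; beyond the scatter) and a 7.7-fold higher number from compound 2 to compound 3 (0.88 log units; beyond the scatter) run toward higher numbers, a further rise beyond the scatter is expected for compound 4. Compound 4 is estimated at 15000 nM, with a range from 3000 nM to 70000 nM, an expected step of a 3.3-fold higher number from compound 3 to compound 4 (0.51 log units; beyond the scatter).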

Compound 4, half-maximal inhibitory concentration: 640000 nM
Compound 4: the middle estimate sits 43-fold (1.63 log units) below what was measured; the whole stated range lies below it.
By their numbers in this assay, from the lowest: compounds 1 and 2 (each within the scatter of the next); then compound 3; then compound 4.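

In this assay, the sulfonyl sulfur proves far less tolerant of losing its aromatic ring than of a change to the group on that ring: methyl in place of the ring gives a 140-fold higher number from compound 3 to compound 4 (2.14 log units; beyond the scatter), then a 1100-fold higher number from compound 2 to compound 4 (3.03 log units; beyond the scatter) and a 1300-fold higher number from compound 1 to compound 4 (3.11 log units; beyond the scatter). All three steps run the same way and are large, none goes against them among these compounds, and compound 4 is the weakest inhibitor of the four, so the earlier variation among 4-methylphenyl, 4-fluorophenyl and 4-ethylphenyl covered only a small part of the range this position can reach. No measurement at hand accounts for the size of this loss.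

As far as these compounds go, an unsubstituted phenyl or a straight butyl chain on the sulfonyl sulfur would help separate the contribution of the aromatic ring from that of the size of the group, and this remains open. From the compounds shown here alone, it also remains open whether a 4-chlorophenyl or 4-methoxyphenyl group would stay close to compound 1 and compound 2 or fall toward compound 3.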